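Thienopyrimidine amides and an ester: cAMP agonism notes

This account rests on a few compounds, and the source may have more. Where it says the series, first, only, none or still open, it means among the compounds named here.

Measured compounds:
compound 1 `COc1cccc(-c2nc(SC)nc3sc(C(=O)NCc4ccccc4)c(N)c23)c1` — "not determined" (no result reported)
compound 2 `CSc1nc(-c2cccc(F)c2)c2c(N)c(C(=O)NC(C)(C)C)sc2n1` — 1200 nM
compound 3 `COc1cccc(-c2nc(SC)nc3sc(C(=O)NCCO)c(N)c23)c1` — "not determined" (no result reported)

Compound 3 has no number in a functional assay on HEK293 cells for agonist activity at lutropin-choriogonadotropic hormone receptor (Homo sapiens), read by cAMP accumulation; a lower number here means that less compound is needed, a higher number that more compound is needed for the effect; its entry stands as not determined, and compound 1 is in the same position. Only compound 2 gives a number in this assay, 1200 nM. Within the data shown here, compound 3 therefore stands nowhere on the numbers: there is nothing to place it above or below compound 2, and no step between any two measured compounds can be computed.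

Compound 4 `COc1cccc(-c2nc(SC)nc3sc(C(=O)OC(C)(C)C)c(N)c23)c1` is the next entry. The change from compound 3 is tert-butoxy in place of (2-hydroxyethyl)amino on a carbonyl carbon; one bond further out, (2-hydroxyethyl)carbamoyl becomes tert-butoxycarbonyl. Among the measured compounds shown here, with no number for compound 3, no size of step in this assay can be stated, nor a direction; the only anchor is compound 2, which shares the core but differs from compound 4 in more than one place.

For the measured compounds named here, compound 4 is expected to land near the single number known for the series, with a wide range and a fair chance of a limit rather than a number: estimate 2000 nM (range 300 nM to 10000 nM).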

Compound 4, half-maximal effective concentration: 1100 nM
Compound 4: the middle estimate sits 1.8-fold (0.26 log units) above what was measured; the measured number falls inside the stated range.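

In this assay compound 4 gives 1100 nM while compound 3 carries no single number, so no step can be read for the change from (2-hydroxyethyl)amino to tert-butoxy. What the compounds shown leave open is the size and direction of any effect of that single change on the shared core. No evidence bears on this result.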